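Adding a Second Hydroxymethyl to the Urea Side Chain

The source may report more compounds than this note shows. Statements on the series, on what has been measured and on what is new or still open speak of the compounds shown alone.

Of the compounds shown here, three sharing one core have been measured in an in vitro functional assay on HEK293 cells for antagonist activity at melanin-concentrating hormone receptor 1 (Homo sapiens), read by GTPgammaS binding, with a stated time of 45 min; on this read-out higher numbers stand for higher potency (the scale is a negative logarithm) and lower numbers for lower potency. Compound 1 `CC(=O)OCC(C)(C)NC(=O)N(CCC1CCN(Cc2ccc(C)cc2)CC1)Cc1ccc(-c2ccccc2)cc1` gives 6.44 in this assay. Compound 2 `Cc1ccc(CN2CCC(CCN(Cc3ccc(-c4cccc(C#N)c4)cc3)C(=O)NC(C)(C)CO)CC2)cc1` gives 7.08. Compound 3 `Cc1ccc(CN2CCC(CCN(Cc3ccc(-c4ccccc4)cc3)C(=O)NC(C)(C)CO)CC2)cc1` gives 6.2, the lowest of the three numbers; its gap to compound 1 lies within the scatter, while its gap to compound 2 lies beyond it. Two single changes connect the measured compounds. Replacing the acetyl on the oxygen by hydrogen gives a number 0.24 log units lower from compound 1 to compound 3 (within the scatter). Replacing the cyano on the aromatic carbon by hydrogen gives a number 0.88 log units lower from compound 2 to compound 3 (beyond the scatter).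

Compound 4 `CCC(CO)(CO)NC(=O)N(CCC1CCN(Cc2ccc(C)cc2)CC1)Cc1ccc(-c2ccccc2)cc1` has not yet been measured. It differs from compound 3 by 1,1-bis(hydroxymethyl)propyl in place of 1-(hydroxymethyl)-1-methylethyl on an amide-type nitrogen. This change sits on the same side chain that was altered between compound 1 and compound 3, where freeing the hydroxyl barely moved the number; the cyano step involving compound 2 concerns a different part of the molecule and does not bear on it. The change is therefore expected to amount to a number 0.10 log units higher from compound 3 to compound 4 (within the scatter), with no move beyond the scatter. Compound 4 is expected to give about 6.3 in this assay, within a range from 5.8 to 6.8.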

Compound 4, negative logarithm of the antagonist equilibrium constant: 6.84
Beside the measured number, compound 4's estimate is 0.54 log units below it; the whole stated range lies below it.
By their numbers in this assay, from the lowest: compounds 3 and 1 (each within the scatter of the next); then compounds 4 and 2 (each within the scatter of the next).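

The side chain on the amide-type nitrogen looked unresponsive while only the acetyl on its oxygen differed, but it does respond to a larger change: in this assay, 1,1-bis(hydroxymethyl)propyl in place of 1-(hydroxymethyl)-1-methylethyl gives a number 0.64 log units higher from compound 3 to compound 4 (beyond the scatter). The same group in place of 1-(acetoxymethyl)-1-methylethyl gives a number 0.40 log units higher from compound 1 to compound 4 (beyond the scatter), so the gain appears against both of the earlier side chains and not just the one with the free hydroxyl. No measurement shown here explains this gain.

The swap alters the side chain in two ways at once, adding a second hydroxymethyl and turning a methyl into an ethyl, and the compounds shown cannot say which of these carries the gain, since 1-(hydroxymethyl)-1-methylpropyl, which has the ethyl without the second hydroxymethyl, is not among them. Also open, as far as these compounds go, are whether the cyano of compound 2 would add to this gain on the same core, and how the number would respond if an amine or a carboxylic acid stood in place of a hydroxymethyl.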